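Compound 3: 4-methoxycyclohexyl in place of 4-hydroxycyclohexyl

This account rests on a few compounds, and the source may have more. Where it says the series, first, only, none or still open, it means among the compounds named here.

Measured in an ADME assay on S9 fraction from liver (Rattus norvegicus) for metabolic stability, with a stated time of 60 min; on this read-out higher numbers stand for a more stable compound and lower numbers for a less stable compound:
- compound 1 `Cc1nc(-c2nc[nH]n2)ccc1-c1cnc2c(n1)N([C@H]1CC[C@@H](O)CC1)C(=O)CN2`: 100%
- compound 2 `Cc1nc(-c2nc[nH]n2)ccc1-c1cnc2c(n1)N(C(C)C)C(=O)CN2`: 100%

Among the measured compounds shown here, compound 1 stands level with compound 2, the only other compound measured so far. Compound 3 `CO[C@H]1CC[C@H](N2C(=O)CNc3ncc(-c4ccc(-c5nc[nH]n5)nc4C)nc32)CC1` is still unmeasured, and its change from compound 1 is 4-methoxycyclohexyl in place of 4-hydroxycyclohexyl on an amide-type nitrogen in a ring. For the measured compounds named here, one measured step bears on it, at the same amide-type nitrogen in a ring: no change at the digits printed from compound 1 to compound 2 (within the scatter). Going by the values given here, no measured compound carries 4-methoxycyclohexyl, so this support is indirect and rests on a single pair. On that evidence, no step beyond the scatter is expected in this assay, and any small movement would be expected to be downward. The expected change is a number 7 percentage points lower from compound 1 to compound 3 (within the scatter). For compound 3 the estimate is 93%, with an expected range of 78% to 100%.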

Compound 3, percent of the compound remaining: 72%
Compound 3: middle estimate off by 21 percentage points, on the high side, outside the stated range (below it).
By their numbers in this assay, from the lowest: compound 3; then compounds 1 and 2 (each within the scatter of the next).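

In this assay, 4-methoxycyclohexyl in place of 4-hydroxycyclohexyl gives a number 28 percentage points lower from compound 1 to compound 3 (beyond the scatter), so a change at the far end of this substituent can move the read-out even with the cyclohexyl ring kept. Set against isopropyl, the same group gives a number 28 percentage points lower from compound 2 to compound 3 (beyond the scatter), which shows that the substituent on this amide-type nitrogen is not always neutral here, as the pair of compound 1 and compound 2 alone might have suggested. Nothing measured on these compounds speaks to what lies behind the lower number.

The swap removes a hydrogen-bond donor and adds a carbon at once, and these two differences cannot be told apart on the present compounds. From the compounds shown here alone, how 4-aminocyclohexyl or plain cyclohexyl on the same nitrogen would read in this assay remains open.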